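The source may report more compounds than this note shows. Statements on the series, on what has been measured and on what is new or still open speak of the compounds shown alone.

Measured compounds in a toxicity assay on the whole organism (strain Icem-CET (SPF Caw)) for cytotoxicity, with Mus musculus as the target; a lower number here means that less compound is needed, a higher number that more compound is needed for the effect:
compound 1 `C#CCNC(=O)/C(C)=C(\C)c1ccc(Br)cc1`: 180 mg/kg
compound 2 `C=CCNC(=O)/C(C)=C(\C)c1ccc(Br)cc1`: 120 mg/kg
compound 3 `C=CCNC(=O)/C(C)=C(\C)c1cc(OC)c(OC)c(OC)c1`: 110 mg/kg

Compound 2 and compound 1 share one core and differ in a single place: ethynyl in place of vinyl on a saturated chain carbon bound to an amide-type nitrogen This change gave a 1.5-fold higher number from compound 2 to compound 1 (0.18 log units; within the scatter). Compound 3 carries another core; the difference between the core of compound 2 and the core of compound 3 is not broken down here. In this assay compound 3 and compound 2 give values that lie close to each other.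

Compound 4 `C#CCNC(=O)/C(C)=C(\C)c1cc(OC)c(OC)c(OC)c1` has not yet been measured. It differs from compound 3 in one place: ethynyl in place of vinyl on a saturated chain carbon bound to an amide-type nitrogen The place reads the same, word for word, as in the change from compound 2 to compound 1, so this is the same change made a second time, now on the core of compound 3. Because a 1.5-fold higher number from compound 2 to compound 1 (0.18 log units; within the scatter) is the only size seen for this change so far, a step of similar size is expected here, a 1.5-fold higher number from compound 3 to compound 4 (0.16 log units; within the scatter). On that basis compound 4 is estimated at 160 mg/kg in this assay, with the expected range running from 90 mg/kg to 280 mg/kg.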

Compound 4, dose for half-maximal effect: 160 mg/kg
Compound 4: middle estimate and measured number agree at the digits printed, within the range that was stated.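

Set side by side, the change from vinyl to ethynyl on a saturated chain carbon bound to an amide-type nitrogen behaves alike on both cores in this assay: the same change on two cores in this assay, a 1.5-fold higher number (0.18 log units; within the scatter) from compound 2 to compound 1 and a 1.5-fold higher number (0.16 log units; within the scatter) from compound 3 to compound 4, 1.0-fold (0.01 log units) apart, within the scatter of two such steps

The new step, a 1.5-fold higher number from compound 3 to compound 4 (0.16 log units; within the scatter), means that the change has now been read on the core of compound 2 and on the core of compound 3, with the same outcome on each. Each step taken alone lies within the scatter, so this agreement does not show that the change truly moves the toxic dose, and two cores give no assurance about any further core in the series.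

Open, on these data alone, is how the number responds when the allyl or propargyl group on the amide nitrogen gives way to a longer chain such as butyl, or to a chain ending in an amine or a carboxylic acid. Also open, as far as these compounds go, is whether the vinyl to ethynyl change reads the same on a core carrying a nitrile or a hydroxyl group.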